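From cyclohexylmethoxy to benzyloxy in compound 3

The compounds below may be only part of what the source reports. "The series", "measured", "known", "first", "only" and "open" are said of these compounds alone.

In a functional assay on HCT-15 cells (Homo sapiens) for antiproliferative activity, read by XTT assay (on this read-out higher numbers stand for weaker inhibition and lower numbers for stronger inhibition), compound 1 `O=c1c(Cc2coc3cccc(OCC4CCCCC4)c3c2=O)coc2ccccc12` gives 4240 nM. Within the data shown here, the only other measured compound, compound 2 `O=c1c(Cc2coc3cccc(OCC4CCCCC4)c3c2=O)coc2cc(O)ccc12`, gives 2110 nM. The pair shows a 2.0-fold lower number from compound 1 to compound 2 (0.30 log units; within the scatter), so compound 1 holds no clearly separate place on the two numbers available.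

Compound 3 `O=c1c(Cc2coc3cccc(OCc4ccccc4)c3c2=O)coc2ccccc12` has not yet been measured. It differs from compound 1 in one place: phenyl in place of cyclohexyl on a saturated chain carbon bound to an oxygen on an aromatic ring. This is phenyl in place of cyclohexyl on a saturated chain carbon bound to an oxygen on an aromatic ring, so cyclohexylmethoxy becomes benzyloxy.

Among the measured compounds shown here, the one measured step is hydroxy in place of hydrogen on an aromatic carbon, and it leaves the cyclohexylmethoxy group untouched. For the measured compounds named here, it therefore bears on this swap only indirectly, and no measured pair exchanges cyclohexyl for phenyl. With so little to go on, no step beyond the scatter is expected in this assay, and neither direction is favoured. The estimate amounts to a 1.2-fold lower number from compound 1 to compound 3 (0.08 log units; within the scatter), which is expected to stay within the scatter. For compound 3 the expected value is 3500 nM, with an estimated range of 1500 nM to 8500 nM.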

Compound 3, half-maximal inhibitory concentration: > 10000 nM
Compound 3: a limit, no number; the forecaster's own chance of this, stated with the estimate: 3%; middle value at least 2.8-fold (0.45 log units) from the limit.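

The reading for compound 3 in this assay is a limit of the assay and not a number: the limit of > 10000 nM in this assay, at which 1 of the 3 values shown sits. Even so, the step can be read in one direction, as an at least 2.3-fold higher number from compound 1 to compound 3 (0.37 log units; beyond the scatter), so the change from cyclohexylmethoxy to benzyloxy weakens inhibition here, even though cyclohexyl and phenyl have the same count of heavy atoms and neither carries a hydrogen-bond donor or acceptor. The earlier pair could not show this: its step, a 2.0-fold lower number from compound 1 to compound 2 (0.30 log units; within the scatter), left the cyclohexylmethoxy group untouched and stayed within the scatter, whereas the present step shows that the assay responds to whether the six-membered ring on this saturated chain carbon is non-aromatic or aromatic.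

The limit leaves the full size of the loss open, and the compounds shown do not say which feature of the phenyl ring lies behind it, or whether hydroxy in place of hydrogen on an aromatic carbon would change the outcome in the benzyloxy series. They also leave open how a cyclopentylmethoxy group, a longer chain such as cyclohexylethoxy, or an amine on the chain would fare at this position.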